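Ring Size on the Amine of an Amide Series

The compounds below may be only part of what the source reports. "The series", "measured", "known", "first", "only" and "open" are said of these compounds alone.

Of the compounds shown here, three of one family have been tested in a functional assay on NALM-6 cells (Homo sapiens) for cytotoxicity, read by MTT assay, with a stated time of 48 h; on this read-out lower numbers stand for stronger inhibition and higher numbers for weaker inhibition. Compound 1, `O=C(Nc1cc(C(F)(F)F)ccc1N1CCCCC1)c1ccccc1`, was reported as "not active" (no number reported). Compound 3, `CCN(CC)c1ccc(C(F)(F)F)cc1NC(=O)c1cccnc1`, gave a value of 63200 nM in this assay. Compound 2, `O=C(Nc1cc(C(F)(F)F)ccc1N1CCCC1)c1cccnc1Cl`, was likewise reported as "not active" (no number reported) in this assay, so no single number marks where compound 2 stands; it sits alongside one further entry that also carries no number, and only compound 3 has a measured value at all.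

The step in question goes from compound 2 to compound 4, `O=C(Nc1cc(C(F)(F)F)ccc1N1CCCCC1)c1cccnc1Cl`. The change is piperidin-1-yl in place of pyrrolidin-1-yl on an aromatic carbon, in words piperidin-1-yl in place of pyrrolidin-1-yl on an aromatic carbon. For the measured compounds named here, no measured pair shows what this change does. Compound 1 carries the same piperidin-1-yl group on a different amide and was reported as not active, and compound 2 was not active either, so there is no sign from either side of the step that this ring enlargement would carry a compound into a measurable range.

The expectation for compound 4 in this assay is therefore a step of no size beyond the scatter, most likely another report of no activity. Compound 4 is estimated at 80000 nM, with a range from 30000 nM to 300000 nM.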

Compound 4, half-maximal inhibitory concentration: "not active" (no number reported)
The entry for compound 4 holds no number; there is nothing to compare the estimate with.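

In this assay compound 2 gives "not active" (no number reported) and compound 4 gives "not active" (no number reported), so neither has a number and no step can be read between them. The compounds shown leave open whether ring size on this amine changes cytotoxicity at all. No measured finding bears on this result.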